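The source may hold more compounds than are shown below. What is called first, only, known or untested is meant among the compounds shown, and "the series" means these compounds.

Working notes on the series. In a functional assay on MDA-MB-231 cells (Homo sapiens) for antiproliferative activity, read by MTT assay, with a stated time of 48 h (on this read-out lower numbers stand for stronger inhibition of growth and higher numbers for weaker inhibition of growth), compound 1 `COC(=O)N1N=C(c2cccc(OC)c2)CC1c1cc(OC)c(OC)c(OC)c1` gives 350 nM and compound 2 `COC(=O)N1N=C(c2cccc(Cl)c2)CC1c1cc(OC)c(OC)c(OC)c1` gives 110 nM as the lower of the two numbers. Among the measured compounds shown here, the only measured step is a 3.2-fold lower number from compound 1 to compound 2 (0.50 log units; beyond the scatter) for chloro in place of methoxy on an aromatic carbon, a modest change beyond the scatter. For the measured compounds named here, compound 3 `COC(=O)N1N=C(c2ccc(O)cc2)CC1c1cc(OC)c(OC)c(OC)c1` carries 4-hydroxyphenyl in place of 3-chlorophenyl on a carbon with a double bond to nitrogen and no measured compound holds that group. Going by the values given here, the one step therefore bears only loosely, as a sign that loss of chloro from compound 2 may cost a step of that modest size. In this assay a higher number is expected, with wide uncertainty. The expected change is a 4.1-fold higher number from compound 2 to compound 3 (0.61 log units; beyond the scatter) as a rough estimate. For compound 3 the estimate is 450 nM with an expected range from 120 nM to 1800 nM on this thin evidence.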

Compound 3, concentration for 50% growth inhibition: 7150 nM
The estimate for compound 3 lay 16-fold (1.20 log units) below the measured number, outside the stated range (above it).
By their numbers in this assay, from the lowest: compound 2; then compound 1; then compound 3.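

In this assay the aryl group on the carbon with a double bond to nitrogen proves much more sensitive than the earlier pair showed: 4-hydroxyphenyl in place of 3-chlorophenyl gives a 65-fold higher number from compound 2 to compound 3 (1.81 log units; beyond the scatter), and 4-hydroxyphenyl in place of 3-methoxyphenyl gives a 20-fold higher number from compound 1 to compound 3 (1.31 log units; beyond the scatter). Both steps are large, whereas the earlier step at this position, a 3.2-fold lower number from compound 1 to compound 2 (0.50 log units; beyond the scatter), is modest. The change at this position can therefore cost far more than the exchange of chloro for methoxy suggested, and nothing in the data presented accounts for the size of these steps.

The 4-hydroxyphenyl group differs from the other two in both its substituent and its place on the ring, so the compounds shown do not separate these two changes. Also open, from the compounds shown here alone, is how 3-hydroxyphenyl, 4-chlorophenyl or an aminophenyl group would stand here.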